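This account rests on a few compounds, and the source may have more. Where it says the series, first, only, none or still open, it means among the compounds named here.

Working notes on the series in an ADME assay on Vero cells (Chlorocebus sabaeus) for cytotoxicity, read by resazurin assay, with a stated time of 72 h; on this read-out higher numbers stand for lower toxicity in this test and lower numbers for higher toxicity in this test. Compound 1 `CC(=O)OC[C@H]1O[C@@H](CC(=O)/C=C2\C(=O)N(Cc3ccccc3)c3ccccc32)[C@H](OC(C)=O)[C@@H](OC(C)=O)[C@@H]1OC(C)=O` gives 71200 nM. Compound 2 `CCCN1C(=O)/C(=C\C(=O)C[C@@H]2O[C@H](COC(C)=O)[C@@H](OC(C)=O)[C@H](OC(C)=O)[C@H]2OC(C)=O)c2cc(Cl)ccc21` gives 95600 nM. Compound 3 `CCCCN1C(=O)/C(=C\C(=O)C[C@@H]2O[C@H](COC(C)=O)[C@@H](OC(C)=O)[C@H](OC(C)=O)[C@H]2OC(C)=O)c2cc(Cl)ccc21` gives 88900 nM; it stands second highest of the three numbers, with compound 2 nearest and compound 1 furthest, both gaps within the scatter, so no order among the three can be read. Among the compounds with values here, the one measured step, a 1.1-fold lower number from compound 2 to compound 3 (0.03 log units; within the scatter), is a lengthening of the chain on the ring nitrogen and shows nothing beyond the scatter.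

Compound 4 `CC(=O)OC[C@H]1O[C@@H](CC(=O)/C=C2\C(=O)N(Cc3ccccc3)c3ccc(Cl)cc32)[C@H](OC(C)=O)[C@@H](OC(C)=O)[C@@H]1OC(C)=O` is not yet measured. It differs from compound 3 by phenyl in place of propyl on a saturated chain carbon bound to an amide-type nitrogen in a ring. Within the data shown here, no measured step covers this change directly; compound 1 carries the same benzyl group on a core lacking the chlorine and sits within the scatter of compound 3. With all three numbers this close, compound 4 is expected to lie near compound 3, so that a 1.1-fold lower number from compound 3 to compound 4 (0.06 log units; within the scatter) is expected to stay within the scatter. Compound 4 is therefore estimated at 78000 nM, with a range from 40000 nM to 150000 nM.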

Compound 4, half-maximal cytotoxic concentration: 91200 nM
Compound 4: middle estimate off by 1.2-fold (0.07 log units), on the low side; measured number inside the range.
By their numbers in this assay, from the lowest: compounds 1, 3, 4 and 2 (each within the scatter of the next).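

Phenyl in place of propyl on a saturated chain carbon bound to an amide-type nitrogen in a ring gives a 1.0-fold higher number from compound 3 to compound 4 (0.01 log units; within the scatter) in this assay and phenyl in place of ethyl at the same place gives a 1.0-fold lower number from compound 2 to compound 4 (0.02 log units; within the scatter), so at this position a ring-bearing benzyl group cannot be told apart from the open chains. Chloro in place of hydrogen on an aromatic carbon, with benzyl held constant, gives a 1.3-fold higher number from compound 1 to compound 4 (0.11 log units; within the scatter), the first measured step for this change and also one that shows nothing beyond the scatter. No measurement is at hand that bears on these results.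

As far as these compounds go, an amine or a carboxylic acid on the chain at this position remains open. So does a free hydroxyl in place of the acetyloxy groups on the shared core.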